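The source may hold more compounds than are shown below. What is called first, only, known or untested is meant among the compounds shown, and "the series" means these compounds.

Three close relatives share one core: an aromatic ring bearing an imidazoline-methylamino group and, on the neighbouring carbon, a small aromatic ring that differs from compound to compound. Compound 1 `c1ccc(-c2cnco2)c(NCC2=NCCN2)c1` carries an oxazole and, in a functional assay for activation of Alpha-1A adrenergic receptor (Homo sapiens), read by calcium flux (a lower number here means that less compound is needed, a higher number that more compound is needed for the effect), compound 1 gives 17.4 nM. Compound 2 `Cc1ccsc1-c1ccccc1NCC1=NCCN1` carries a methylthiophene, and in this assay compound 2 gives 0.851 nM. Compound 3 `Cc1noc(-c2ccccc2NCC2=NCCN2)n1` carries a methyl-oxadiazole, and in this assay compound 3 gives 661 nM, the highest of the three numbers: the steps are a 38-fold higher number from compound 1 to compound 3 (1.58 log units; beyond the scatter) and a 780-fold higher number from compound 2 to compound 3 (2.89 log units; beyond the scatter), both large and both beyond the scatter.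

Compound 4 `c1cnc(-c2ccccc2NCC2=NCCN2)nc1` makes one change to compound 3: pyrimidin-2-yl in place of 3-methyl-1,2,4-oxadiazol-5-yl on an aromatic carbon. The measured steps show that this ring is a sensitive spot. Swapping the oxadiazole for an oxazole gave a 38-fold higher number from compound 1 to compound 3 (1.58 log units; beyond the scatter) read in reverse, and for a methylthiophene a 780-fold higher number from compound 2 to compound 3 (2.89 log units; beyond the scatter) in reverse, so a six-membered ring with fewer hetero atoms is expected to move the number downward, though how far a pyrimidine goes is not settled by these three compounds. A step of an 11-fold lower number from compound 3 to compound 4 (1.04 log units; beyond the scatter) is expected. For compound 4 the estimate in this assay is 60 nM, with a range from 10 nM to 400 nM.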

Compound 4, half-maximal effective concentration: 10 nM
Compound 4: middle estimate off by 6.0-fold (0.78 log units), on the high side; low and high end bracket the measured number.
By their numbers in this assay, from the lowest: compound 2; then compounds 4 and 1 (each within the scatter of the next); then compound 3.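

Replacing the 3-methyl-1,2,4-oxadiazol-5-yl with pyrimidin-2-yl gives a 66-fold lower number from compound 3 to compound 4 (1.82 log units; beyond the scatter) in this assay, which shows that this position accepts a six-membered aromatic ring and that the five-membered rings seen so far are not required for a low number. Set against the oxazole, the pyrimidine gives a 1.7-fold lower number from compound 1 to compound 4 (0.24 log units; within the scatter) and so cannot be told apart from it, even though the two rings differ in size; ring size alone therefore does not decide the outcome here, since two five-membered rings, the oxazole of compound 1 and the oxadiazole of compound 3, lie far apart. The pyrimidine still falls short of the methylthiophene, with a 12-fold higher number from compound 2 to compound 4 (1.07 log units; beyond the scatter) and a gap beyond the scatter, so compound 2 keeps the lowest number of the four.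

Nothing available explains why these rings give such different numbers. From the compounds shown here alone, how a plain phenyl ring, a pyridine or a non-aromatic group such as a small amine would behave on this aromatic carbon remains open, as does whether a methyl group on the pyrimidine would lower the number further.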